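Notes on a hydroxy-for-amino swap in the series

The source may hold more compounds than are shown below. What is called first, only, known or untested is meant among the compounds shown, and "the series" means these compounds.

compound 1 `O=C1CN(S(=O)(=O)c2cc3ccc(Cl)cc3s2)CCN1Cc1cc2cc[nH]cc-2n1` — in an assay on isolated protein for binding affinity to serine protease 1 (Homo sapiens) (a lower number here means a stronger inhibitor, a higher number a weaker inhibitor), compound 1 gives > 2900 nM, a limit of the assay and not a number.
compound 2 `Nc1[nH]ccc2nc(CN3CCN(S(=O)(=O)c4cc5ccc(Cl)cc5s4)CC3=O)cc1-2` — in this assay compound 2 gives > 2900 nM, likewise a limit.

The step that the two limits leave unreadable from compound 1 to compound 2 is not readable, since both values sit at the limit of > 2900 nM in this assay, at which 2 of the 2 values shown sit. Compound 2 therefore stands only at that limit, with no number of its own.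

Compound 3 `O=C1CN(S(=O)(=O)c2cc3ccc(Cl)cc3s2)CCN1Cc1cc2c(O)[nH]ccc-2n1` differs from compound 2 by hydroxy in place of amino on an aromatic carbon, a hydroxy in place of amino on an aromatic carbon. Among the measured compounds shown here, no measured step bears on this change; the one step recorded has no readable size. The expectation for compound 3 rests on the limit of compound 2 alone.

Compound 3 is expected to give about 6000 nM in this assay, within a range of 2000 nM to 30000 nM, most probably reported again as a limit. The expected step that the limit leaves unreadable from compound 2 to compound 3 is none beyond the scatter.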

Compound 3, inhibition constant: > 2900 nM
Compound 3: no number, only a limit; the forecaster's own chance of this, stated with the estimate: 80%; the middle value lies beyond the limit too.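

Compound 3 in this assay gives > 2900 nM as a limit and not a number. Among the compounds shown here, no step among compound 1, compound 2 and compound 3 can be read: the limit of > 2900 nM in this assay, at which 3 of the 3 values shown sit. The compounds shown leave open whether hydroxy in place of amino on an aromatic carbon changes binding affinity at all.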